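The compounds below may be only part of what the source reports. "The series", "measured", "known", "first", "only" and "open" are said of these compounds alone.

For the measured compounds named here, compound 2 `CCn1c(=O)c2c(nc(Cc3ccco3)n2C)n(Cc2ccco2)c1=O` sits at 13.8 nM in an assay on HEK293 cells for displacement of a labelled ligand from adenosine receptor A2b (Homo sapiens) (a lower number here means a stronger inhibitor, a higher number a weaker inhibitor), the higher of the two numbers measured so far, with compound 1 `CCn1c(=O)c2c(nc(Cc3ccccc3)n2C)n(Cc2ccco2)c1=O` close by at 12.9 nM. Compound 3 `CCn1c(=O)c2c(nc(Cc3cccs3)n2C)n(Cc2ccco2)c1=O` differs from compound 2 by thiophen-2-yl in place of furan-2-yl on a saturated chain carbon bound to an aromatic carbon. Going by the values given here, the one comparable step, a 1.1-fold higher number from compound 1 to compound 2 (0.03 log units; within the scatter), shows that exchanging the aromatic ring on this saturated chain carbon left this assay essentially unchanged, so a similar outcome is expected here, with no step beyond the scatter in either direction. Compound 3 is therefore expected to give about 12 nM, between 6 nM and 25 nM, which corresponds to an expected step of a 1.2-fold lower number from compound 2 to compound 3 (0.06 log units; within the scatter).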

Compound 3, inhibition constant: 7.41 nM
For compound 3 the middle estimate is 1.6-fold (0.21 log units) above the measured one; the measured number falls inside the stated range.
By their numbers in this assay, from the lowest: compounds 3, 1 and 2 (each within the scatter of the next).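

Swapping the ring oxygen of furan-2-yl for the sulfur of thiophen-2-yl gives a 1.9-fold lower number from compound 2 to compound 3 (0.27 log units; within the scatter) in this assay, while thiophen-2-yl in place of phenyl gives a 1.7-fold lower number from compound 1 to compound 3 (0.24 log units; within the scatter). With this third aromatic ring, and with both five-membered and six-membered rings now represented, this saturated chain carbon still shows no step beyond the scatter among the three compounds. Nothing available offers an explanation for these numbers. Still open, from the compounds shown here alone, is whether this position would tolerate something other than an aromatic ring, such as an amine, a carboxylic acid or a cyclohexyl group.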